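Antipurine glycinamide esters: amide to benzyl ester step

The source may hold more compounds than are shown below. What is called first, only, known or untested is meant among the compounds shown, and "the series" means these compounds.

Measured so far:
compound 1, `O=C(CN(c1nc(Cl)nc2[nH]cnc12)C1CC1)N[C@@H](CO)C(=O)OCc1ccccc1`, with 34.5%
compound 2, `NC(=O)CC[C@H](NC(=O)CN(c1ncnc2c1ncn2C1CCCCO1)C1CC1)C(=O)OCc1ccccc1`, with 37.8%

In a functional assay on the whole organism (Tail, strain ICR) with Mus musculus as the target, in the tail flick test, with a stated time of 90 min, at a dose of 25 umol/kg by the oral route (a higher number here means a stronger effect of the compound at the dose given, a lower number a weaker effect), compound 1 gives 34.5%. In this assay compound 2 gives 37.8%. The two numbers lie within the usual scatter of each other, so the data do not separate compound 2 from compound 1; compound 2 simply sits at the upper of the two numbers. For the measured compounds named here, the two compounds differ in more than one place and no single step between them can be read.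

Compound 3, `O=C(CN(c1ncnc2c1ncn2C1CCCCO1)C1CC1)N[C@@H](CCC(=O)OCc1ccccc1)C(=O)OCc1ccccc1`, is not yet measured. It differs from compound 2 as follows: benzyloxy in place of amino on a carbonyl carbon. Going by the values given here, no measured pair shows what this kind of change does in this assay. The expectation is therefore a step of about a number 1.8 percentage points lower from compound 2 to compound 3 (within the scatter) in this assay, none beyond the scatter, with a wide range to reflect the lack of a precedent. Compound 3 is estimated at 36% in this assay, between 16% and 56%.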

Compound 3, a percentage reported as activity, at one dose (the size of the read-out at that dose, not a potency): 25.2%
For compound 3 the middle estimate is 10.8 percentage points above the measured one, within the range that was stated.
By their numbers in this assay, from the lowest: compounds 3, 1 and 2 (each within the scatter of the next, the first and the last beyond it).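

Working from this assay, the change of 2-carbamoylethyl to 2-(benzyloxycarbonyl)ethyl gives the first single-place step in the series: a number 12.6 percentage points lower from compound 2 to compound 3 (beyond the scatter). This position is therefore not neutral in this read-out, since benzyloxy in place of amino on a carbonyl carbon moves the number by more than the scatter, although compound 3 still gives 25.2% at the dose used. Nothing on hand bears on the reason for this step.

From the compounds shown here alone, it remains open whether the step follows the departure of amino or the arrival of benzyloxy; a carboxylic acid or a methyl ester on the same carbonyl carbon would help separate the two. For the compounds shown here, no step to compound 1 can be read, as it differs from compound 2 and compound 3 in more than one place.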